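A few compounds are considered here, and "the series" means these few. Any claim that something is new, unique, unknown or untested is made for them only; others in the source may bear on it.

Three compounds have been measured in an ADME assay on HaCaT cells (Homo sapiens) for antiproliferative activity, read by MTT assay, with a stated time of 48 h; a higher number here means a weaker inhibitor, a lower number a stronger inhibitor:

Compound 1 `O=C(/C=C\Nc1ccc(F)cc1)c1cn(-c2ccccc2)nc1-c1ccccc1` gives 34200 nM.
Compound 2 `O=C(/C=C\Nc1ccc(O)cc1)c1cn(-c2ccccc2)nc1-c1ccc(Cl)cc1` gives 22600 nM.
Compound 3 `COc1ccc(-c2nn(-c3ccccc3)cc2C(=O)/C=C\Nc2ccc(F)cc2)cc1` gives 8910 nM.

Compound 3 stands lowest of the three numbers; its nearest neighbour is compound 2 and its furthest is compound 1, and both gaps are beyond the scatter. For the measured compounds named here, only one single-point step can be drawn among the measured compounds: a 3.8-fold lower number from compound 1 to compound 3 (0.58 log units; beyond the scatter). Compound 4 `COc1ccc(-c2nn(-c3ccccc3)cc2C(=O)/C=C\Nc2ccc(O)cc2)cc1` differs from compound 3 in one place: hydroxy in place of fluoro on an aromatic carbon. Going by the values given here, no measured step bears directly on this change. Compounds 1 and 2 carry fluoro and hydroxy at the same place on the anilino ring, but they also differ elsewhere, so their two values can only be read side by side: compound 1 gives 34200 nM and compound 2 gives 22600 nM, numbers that are not far apart. On that thin basis the step in this assay from compound 3 to compound 4 is expected to be small, most likely within the scatter, with a slight lean toward a lower number: a 1.3-fold lower number from compound 3 to compound 4 (0.10 log units; within the scatter). Compound 4 is therefore estimated at 7000 nM, with a range from 3000 nM to 18000 nM.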

Compound 4, half-maximal inhibitory concentration: 34600 nM
Compound 4: middle estimate off by 4.9-fold (0.69 log units), on the low side; the whole stated range lies below it.
By their numbers in this assay, from the lowest: compound 3; then compounds 2, 1 and 4 (each within the scatter of the next).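

In this assay, for the compounds shown here, the exchange of (4-fluorophenyl)amino for (4-hydroxyphenyl)amino can now be read directly for the first time, and it gives a 3.9-fold higher number from compound 3 to compound 4 (0.59 log units; beyond the scatter). With hydroxy held at this place, methoxy in place of chloro on the other aromatic ring gives a 1.5-fold higher number from compound 2 to compound 4 (0.18 log units; within the scatter), so that single change does not separate compound 2 from compound 4. Going by these compounds alone, the low number of compound 3 therefore does not survive the exchange of fluoro for hydroxy in the one pair that tests it, and the step seen earlier on adding methoxy, a 3.8-fold lower number from compound 1 to compound 3 (0.58 log units; beyond the scatter), was read only with fluoro at this place.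

Nothing available gives a reason for the size or direction of this step. Going by these compounds, it remains open whether the higher number is particular to hydroxy or would also follow from an amine or a carboxylic acid at this place on the ring, and whether the exchange of fluoro for hydroxy would give a similar step with hydrogen or chloro on the other aromatic ring.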